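Shrinking an Alkoxy Group on an Imidazoline Ligand

The source may report more compounds than this note shows. Statements on the series, on what has been measured and on what is new or still open speak of the compounds shown alone.

Measured compounds:
Compound 1, `CCOc1ccccc1OC(C)C1=NCCN1`, in an assay on CHO cells for displacement of a labelled ligand from Alpha-2C adrenergic receptor (Homo sapiens) (on this read-out lower numbers stand for stronger inhibition and higher numbers for weaker inhibition), compound 1 gives 759 nM.
Compound 2, `CC(Oc1ccccc1OC1CC1)C1=NCCN1`, in this assay compound 2 gives 676 nM.

Among the compounds with values here, compound 2 has the lowest of the two numbers measured so far, but the separation is small: a 1.1-fold lower number from compound 1 to compound 2 (0.05 log units; within the scatter), so compound 1 and compound 2 cannot be told apart on this read-out.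

Compound 3, `COc1ccccc1OC(C)C1=NCCN1`, has not been measured. It differs from compound 2 in one place: methyl in place of cyclopropyl on an oxygen on an aromatic ring. Within the data shown here, only one measured step touches this position. Swapping ethyl for cyclopropyl gave a 1.1-fold lower number from compound 1 to compound 2 (0.05 log units; within the scatter), so that exchange of groups on the oxygen left the number essentially unchanged. Among the measured compounds shown here, the exchange for methyl has no measured counterpart. For the measured compounds named here, whether it matters cannot be read from the two compounds measured so far. On the evidence at hand, the expected change from compound 2 to compound 3 is a 1.1-fold higher number from compound 2 to compound 3 (0.05 log units; within the scatter), that is, no step beyond the scatter in either direction. Compound 3 is therefore estimated at 750 nM in this assay, with a plausible range from 300 nM to 1900 nM.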

Compound 3, inhibition constant: 832 nM
The estimate for compound 3 lay 1.1-fold (0.05 log units) below the measured number; low and high end bracket the measured number.
By their numbers in this assay, from the lowest: compounds 2, 1 and 3 (each within the scatter of the next).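

With methyl on the oxygen, the third group at this position can now be compared with the other two, and the result in this assay is again a step too small to read: cyclopropyl to methyl gives (a 1.2-fold higher number from compound 2 to compound 3 (0.09 log units; within the scatter)), and the shorter change from ethyl to methyl gives (a 1.1-fold higher number from compound 1 to compound 3 (0.04 log units; within the scatter)). Before this result, only the exchange of ethyl for cyclopropyl could be judged, so a single pair stood behind the idea that this oxygen substituent makes little difference; now all three pairs among methyl, ethyl and cyclopropyl lie within the scatter, and neither removing a carbon from the chain nor removing the three-membered ring separates the compounds on this read-out. Nothing available explains why these three groups read alike.

These three groups are all small and made only of carbon and hydrogen, so the compounds shown leave open whether a longer chain such as hexyl, a benzyl group or an amine on this oxygen would give a step beyond the scatter. They also leave open how a bare hydroxyl, with hydrogen on this oxygen, would read in this assay.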